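The source may report more compounds than this note shows. Statements on the series, on what has been measured and on what is new or still open speak of the compounds shown alone.

Compound 1 `OC[C@H]1O[C@@H](n2cnc3c(NCc4ccc(Cl)c(Cl)c4)ncnc32)[C@H](O)[C@@H]1O` — > 166000 nM
Compound 2 `COc1cc(CNc2ncnc3c2ncn3[C@@H]2O[C@H](CO)[C@@H](O)[C@H]2O)cc(OC)c1O` — > 166000 nM
Compound 3 `COc1cc(O)cc(OC)c1CNc1ncnc2c1ncn2[C@@H]1O[C@H](CO)[C@@H](O)[C@H]1O` — > 166000 nM

The three compounds share a common core and differ in the group carried on the saturated chain carbon bound to a nitrogen on the aromatic ring. In a functional assay on HOS cells (Homo sapiens) for antiproliferative activity, with a stated time of 72 h (on this read-out lower numbers stand for stronger inhibition and higher numbers for weaker inhibition), compound 1 gives > 166000 nM, and this is a limit of the assay rather than a number. In this assay compound 2 likewise gives only a limit, > 166000 nM. For compound 3 the outcome in this assay is again a limit, > 166000 nM. Compound 1 therefore cannot be placed above or below the other two; all that is known is the limit of > 166000 nM in this assay, at which 3 of the 3 values shown sit.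

Compound 4 `OC[C@H]1O[C@@H](n2cnc3c(NCc4cccc(C(F)(F)F)c4)ncnc32)[C@H](O)[C@@H]1O` is the next member of the series. Compared with compound 1 it carries 3-(trifluoromethyl)phenyl in place of 3,4-dichlorophenyl on a saturated chain carbon bound to a nitrogen on an aromatic ring.

Going by the values given here, no step between two measured compounds is available, so there is no measured size of change to lean on. Since every measured member sits at the limit, the step from compound 1 to compound 4 is expected to be none beyond the scatter, a step that the limit leaves unreadable from compound 1 to compound 4, with the real possibility that only a limit is reported again. For compound 4 the expected value in this assay is 200000 nM, within a range from 40000 nM to 1000000 nM.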

Compound 4, half-maximal inhibitory concentration: > 166000 nM
Compound 4 was reported as a limit (the forecaster's own chance of this, stated with the estimate: 80%); the middle value is on the limit's open side.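

In this assay compound 4 gives > 166000 nM, which is a limit of the assay and not a number. Compound 1 is also reported only as a limit, so no step can be read between compound 1 and compound 4. The compounds shown leave open whether changing the group on the shared core alters the read-out at all: the limit of > 166000 nM in this assay, at which 4 of the 4 values shown sit.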